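Replacing a cyclopentyl by isopropyl in a weak modulator

A few compounds are considered here, and "the series" means these few. Any claim that something is new, unique, unknown or untested is made for them only; others in the source may bear on it.

Compound 1: `Cc1c(OCCCCOc2ccc(C(=O)O)cc2)ccc(C(=O)CC2CCCC2)c1O` — > 10000 nM
Compound 2: `Cc1c(OCCCCOc2ccc(C(=O)O)cc2)ccc(C(=O)CC2CCCC2)c1C` — "not determined" (no result reported)

In an assay on HEK293 cells for positive allosteric modulation of metabotropic glutamate receptor 3 (Rattus norvegicus), read by thallium flux, with a stated time of 2.5 min (on this read-out higher numbers stand for an effect only at larger amounts of compound and lower numbers for an effect already at smaller amounts), compound 1 gives > 10000 nM, which is a limit of the assay rather than a number. Compound 1 therefore stands at the limit of > 10000 nM in this assay, at which 1 of the 2 values shown sits, and no single value can be placed against it. For compound 2 this assay has "not determined" (no result reported), so it adds no number either.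

Compound 3 is `Cc1c(OCCCCOc2ccc(C(=O)O)cc2)ccc(C(=O)CC(C)C)c1O`. It differs from compound 1 in one place: isopropyl in place of cyclopentyl on a saturated chain carbon bound to a carbonyl carbon. Both carbon groups sit on a saturated chain carbon bound to a carbonyl carbon, and neither brings a donor, an acceptor or a charge.

For the measured compounds named here, with compound 1 already at the limit, there is no measured step from which to read a direction. The step from compound 1 to compound 3 is expected to be a step that the limit leaves unreadable from compound 1 to compound 3, that is, nothing beyond the scatter. Compound 3 is estimated to give 15000 nM, in a range from 4000 nM to 60000 nM, most likely again only as a limit.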

Compound 3, half-maximal effective concentration: 2720 nM
For compound 3 the middle estimate is 5.5-fold (0.74 log units) above the measured one; the whole stated range lies above it.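

The place on a saturated chain carbon bound to a carbonyl carbon turns out to matter for activity: in this assay, isopropyl in place of cyclopentyl gives an at least 3.6-fold lower number from compound 1 to compound 3 (0.56 log units; beyond the scatter). For the compounds shown here, the shared core can therefore give a real number when the five-membered ring gives way to an open group with fewer heavy atoms, and compound 3 is the only compound here with a value against which further changes can be set. The true size of the step stays unknown because compound 1 rests on a limit rather than a number: the limit of > 10000 nM in this assay, at which 1 of the 3 values shown sits.

This single pair cannot separate the loss of the ring from the loss of carbons. A cyclopropyl or a tert-butyl at the same place would speak to that, and a plain methyl would show how far the group can shrink.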